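Tetrazole in Place of Acetyl on the Shared Core

This account rests on a few compounds, and the source may have more. Where it says the series, first, only, none or still open, it means among the compounds named here.

In a functional assay for inhibition, with Homo sapiens as the target (on this read-out higher numbers stand for weaker inhibition and lower numbers for stronger inhibition), compound 3 `CC(=O)c1cc(-c2ccccc2)c2ccc(OCc3cccc(C4(O)CCOCC4)c3)cc2c1` gives 2 nM and stands lowest of the three numbers measured. Compound 1 `CC(O)c1cc(-c2ccccc2)c2ccc(OCc3cccc(C4(O)CCOCC4)c3)cc2c1` gives 28 nM and compound 2 `COC(C)c1cc(-c2ccccc2)c2ccc(OCc3cccc(C4(O)CCOCC4)c3)cc2c1` gives 41 nM in this assay. The two steps onto compound 3 are large: a 14-fold lower number from compound 1 to compound 3 (1.15 log units; beyond the scatter) and a 21-fold lower number from compound 2 to compound 3 (1.31 log units; beyond the scatter), while a 1.5-fold higher number from compound 1 to compound 2 (0.17 log units; within the scatter). Compound 4 `Cn1nnnc1-c1cc(-c2ccccc2)c2ccc(OCc3cccc(C4(O)CCOCC4)c3)cc2c1` carries the change (1-methyl-1H-tetrazol-5-yl in place of acetyl on an aromatic carbon). Among the measured compounds shown here, no measured step replaces the acetyl with an aromatic ring, so the comparison rests only on the fact that both departures from acetyl seen so far gave much higher numbers. Compound 4 is therefore expected to show a higher number than compound 3, estimated as a 7.5-fold higher number from compound 3 to compound 4 (0.88 log units; beyond the scatter). The estimate for compound 4 is 15 nM, within 4 nM to 60 nM.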

Compound 4, half-maximal inhibitory concentration: > 67 nM
Compound 4: a limit, no number; the forecaster's own chance of this, stated with the estimate: 2%; middle value at least 4.4-fold (0.64 log units) from the limit.
By their numbers in this assay, from the lowest: compound 3; then compounds 1 and 2 (each within the scatter of the next). At a limit, above all of these: compound 4.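

In this assay, compound 4 gives a limit and not a number: the limit of > 67 nM in this assay, at which 1 of the 4 values shown sits. Even so, an aromatic five-membered ring with 4 hetero atoms, 1-methyl-1H-tetrazol-5-yl, is far from a match for acetyl at this position, with an at least 33-fold higher number from compound 3 to compound 4 (1.52 log units; beyond the scatter). The same change shows an at least 2.3-fold higher number from compound 1 to compound 4 (0.37 log units; beyond the scatter), which sets compound 4 clear of compound 1, but an at least 1.6-fold higher number from compound 2 to compound 4 (0.21 log units; that floor lies within the scatter), which leaves its separation from compound 2 unsettled.

From the compounds shown here alone, how far compound 4 lies past its limit remains open. So does whether a nitrile, a primary amide or a carboxylic acid at this position would stay close to acetyl.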